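The source may hold more compounds than are shown below. What is called first, only, known or untested is meant among the compounds shown, and "the series" means these compounds.

Working notes on the series. In an ADME assay on microsomes from liver (Rattus norvegicus) for metabolic stability, using NADPH, with a stated time of 10 min (on this read-out lower numbers stand for a less stable compound and higher numbers for a more stable compound), compound 2 `CN1C[C@@H]2CN(c3cccc4c3C[C@H](CN(C)[C@H]3CCCc5cccnc53)NC4)C[C@@H]2C1` gives 35.3% and stands highest of the three measured compounds; compound 1 `CN1CCN(Nc2cccc3c2C[C@@H](CN(C)[C@H]2CCCc4cccnc42)NC3)CC1` gives 21%, and compound 3 `CN(C)[C@@H]1CCN(c2cccc3c2C[C@H](CN(C)[C@H]2CCCc4cccnc42)NC3)C1` gives 3.88%, both beyond the scatter below compound 2. Compound 4 `CN(C)[C@H]1CCN(c2cccc3c2C[C@H](CN(C)[C@H]2CCCc4cccnc42)NC3)C1` is not yet measured. It differs from compound 2 by a group of 8 heavy atoms (6 carbon, 2 nitrogen; one five-membered non-aromatic ring with 1 hetero atom) in place of a group of 9 heavy atoms (7 carbon, 2 nitrogen; 2 five-membered non-aromatic rings with 1 hetero atom each), on an aromatic carbon. Within the data shown here, the one measured step bearing on this change is the step in this assay from compound 2 to compound 3, a number 31.4 percentage points lower from compound 2 to compound 3 (beyond the scatter), which carries the same change in words. A step of comparable direction, downward and beyond the scatter, is therefore expected in this assay for compound 4, though its size is uncertain because compound 3 gives 3.88% after a change that differs in its one defined stereocentre. Compound 4 is estimated at 9%, range 2% to 26%, meaning an expected step of a number 26.3 percentage points lower from compound 2 to compound 4 (beyond the scatter).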

Compound 4, percent of the compound remaining: 4.55%
Beside the measured number, compound 4's estimate is 4.5 percentage points above it; the range from low to high includes it.
By their numbers in this assay, from the lowest: compounds 3 and 4 (each within the scatter of the next); then compound 1; then compound 2.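

The exchange of the group of compound 2 for 3-(dimethylamino)pyrrolidin-1-yl on this aromatic carbon gives in this assay a number 30.8 percentage points lower from compound 2 to compound 4 (beyond the scatter), so the large drop is now seen with both drawn configurations of the group and is not tied to one of them. The saturated ring stereocentre does not separate the pair, with a number 0.7 percentage points higher from compound 3 to compound 4 (within the scatter). Still open, going by these compounds, is which feature of the entering group goes with the drop, and where a morpholine or an open-chain dimethylaminoethyl amine on the same carbon would stand in this assay.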